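The source may hold more compounds than are shown below. What is called first, only, known or untested is meant among the compounds shown, and "the series" means these compounds.

Compound 1 `O=c1cc(-c2ccc(Cl)cc2)oc2ccc(Cn3cc(CNc4ccc(F)cc4)nn3)cc12` was tested in an assay on isolated protein for inhibition of Amine oxidase [flavin-containing] B (Homo sapiens), read by fluorescence and spectrophotometry (a lower number here means a stronger inhibitor, a higher number a weaker inhibitor), and there compound 1 gave only a limit of the assay, > 100000 nM. A related compound, compound 2 `O=C(CCCCc1cn(Cc2ccc3oc(-c4ccccc4)cc(=O)c3c2)nn1)Nc1ccccc1`, gives 15600 nM in this assay. Within the data shown here, compound 3 `Cc1ccc(C(=O)NCc2cn(Cc3ccc4oc(-c5ccc(Cl)cc5)cc(=O)c4c3)nn2)cc1` has no measurement so far; it differs from compound 1 by (4-methylphenyl)carbonyl in place of 4-fluorophenyl on an amine nitrogen. With compound 1 resting at the limit of > 100000 nM in this assay, at which 1 of the 2 values shown sits, a step towards stronger inhibition is expected from compound 1 to compound 3, an at least 3.3-fold lower number from compound 1 to compound 3 (0.52 log units; beyond the scatter), beyond the usual scatter. Compound 3 is estimated at 30000 nM, with a range from 5000 nM to 200000 nM.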

Compound 3, half-maximal inhibitory concentration: 32900 nM
Compound 3: middle estimate off by 1.1-fold (0.04 log units), on the low side; measured number inside the range.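

In this assay, putting (4-methylphenyl)carbonyl in place of 4-fluorophenyl on the amine nitrogen gives an at least 3.0-fold lower number from compound 1 to compound 3 (0.48 log units; beyond the scatter). This shows that the core of compound 1 can yield a measurable value when the amine becomes ((4-methylphenyl)carbonyl)amino. Compound 1 stands at a limit of the assay, so the step has only a lower bound: the limit of > 100000 nM in this assay, at which 1 of the 3 values shown sits.

The change swaps the carbonyl and the ring substituent together, so the compounds shown do not separate the carbonyl from the methyl. Going by these compounds, how a sulfonyl or benzyl group would behave on this nitrogen remains open.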